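The source may report more compounds than this note shows. Statements on the series, on what has been measured and on what is new or still open speak of the compounds shown alone.

Measured compounds:
- compound 1, `C/C=C/C(=O)N(Cc1cccc(O)c1)c1cc(OC)c(OC)c(OC)c1`, gives 6700 nM in a functional assay on HCT-116 cells (Homo sapiens) for inhibition, read by MTT assay, with a stated time of 48 h; a lower number here means a stronger inhibitor, a higher number a weaker inhibitor
- compound 2, `COc1ccc(CNc2cc(OC)c(OC)c(OC)c2)cc1[N+](=O)[O-]`, gives 18200 nM
- compound 3, `COc1cc(NCc2cccc(O)c2)cc(OC)c1OC`, gives 67700 nM

Compound 1 gives the lowest number of the three, with compound 2 next and compound 3 furthest away. For the measured compounds named here, the one single-point step among them, a 10-fold higher number from compound 1 to compound 3 (1.00 log units; beyond the scatter), concerns the amide-type nitrogen and not the aryl group that is changed here, so it does not speak directly to the new compound. Compounds 2 and 3 differ in their aryl groups but also in the substituents on them, so their two values only show that such a swap can shift the number.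

The unmeasured compound 4, `C/C=C/C(=O)N(Cc1ccc(OC)c(N)c1)c1cc(OC)c(OC)c(OC)c1`, differs from compound 1 by 3-amino-4-methoxyphenyl in place of 3-hydroxyphenyl on a saturated chain carbon bound to an amide-type nitrogen. Going by the values given here, no measured step covers this exact change, so the expectation rests on the general size of aryl swaps seen in compounds 2 and 3. Compound 4 is expected to sit close to compound 1, with a modest step of a 2.7-fold lower number from compound 1 to compound 4 (0.43 log units; beyond the scatter) toward a lower number. The estimate for compound 4 is 2500 nM, within 500 nM to 12000 nM.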

Compound 4, half-maximal inhibitory concentration: 300 nM
Estimate against measurement, compound 4: 8.3-fold (0.92 log units) above; measured number below the stated range.
By their numbers in this assay, from the lowest: compound 4; then compound 1; then compound 2; then compound 3.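

Swapping the group on the saturated chain carbon bound to an amide-type nitrogen, with the rest of the molecule unchanged, gives a large change in this assay, with a 22-fold lower number from compound 1 to compound 4 (1.35 log units; beyond the scatter). For the compounds shown here, this position therefore has a strong influence on the number, which the earlier compounds could not show because none of them formed a single-point pair changing this group. No measurement shown here explains the size of this step.

The swap removes a hydroxyl group and brings in both an amino group and a methoxy group, so the compounds shown leave open how much of the step belongs to each. Also open, as far as these compounds go, is what an amine with added carbons, such as dimethylamino, or a carboxylic acid would do on this ring.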